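Bromo to methoxy in the series: working notes

The source may report more compounds than this note shows. Statements on the series, on what has been measured and on what is new or still open speak of the compounds shown alone.

Compound 1 `c1ccc(COc2ccc(C3CC(c4ccc5c(c4)OCCO5)=NN3c3ccccc3)cc2)cc1`: 1130 nM
Compound 2 `Brc1ccc(C2CC(c3ccc4c(c3)OCCO4)=NN2c2ccccc2)cc1`: 3010 nM

In a functional assay on WM 266-4 cells (Homo sapiens) for antiproliferative activity, read by MTT assay, with a stated time of 24 h (on this read-out higher numbers stand for weaker inhibition of growth and lower numbers for stronger inhibition of growth), compound 2 holds the higher of the two numbers at 3010 nM, so it is the weaker growth inhibitor of the pair. Compound 3 `COc1ccc(C2CC(c3ccc4c(c3)OCCO4)=NN2c2ccccc2)cc1` is not yet measured and differs from compound 2 by one change: methoxy in place of bromo on an aromatic carbon. This is methoxy in place of bromo on an aromatic carbon, para to a large group. For the measured compounds named here, one measured step bears on it, a modest one with bromo in place of benzyloxy: a 2.7-fold higher number from compound 1 to compound 2 (0.43 log units; beyond the scatter). Read in reverse, that step points toward a lower number when bromo leaves, although no methoxy compound has been measured to confirm it. A step of similar or smaller size is therefore expected in this assay. The expected change is a 1.7-fold lower number from compound 2 to compound 3 (0.22 log units; within the scatter). For compound 3 the estimate is 1800 nM, with an expected range of 800 nM to 4000 nM.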

Compound 3, concentration for 50% growth inhibition: > 100000 nM
Compound 3 gave a limit, no number (the forecaster's own chance of this, stated with the estimate: 3%); middle value at least 55-fold (1.74 log units) away from the limit.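

Compound 3 gives only a limit, not a number, in this assay: the limit of > 100000 nM in this assay, at which 1 of the 3 values shown sits.

At this position, para to a large group, methoxy in place of bromo gives an at least 33-fold higher number from compound 2 to compound 3 (1.52 log units; beyond the scatter), and removing the phenyl from the benzyloxy group gives an at least 88-fold higher number from compound 1 to compound 3 (1.94 log units; beyond the scatter), both far larger than the modest 2.7-fold higher number from compound 1 to compound 2 (0.43 log units; beyond the scatter). An oxygen on the aromatic carbon therefore does not by itself keep a measured number, since compound 1 has one and gives a number while compound 3 has one and gives only a limit, and compound 2 has none and gives a number.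

The compounds shown do not tell why methoxy differs so sharply from bromo and benzyloxy. From the compounds shown here alone, whether chloro, an ethoxy group or an amine at this position would restore a measured number remains open.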